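Turning One Double Bond in Compound 2

A few compounds are considered here, and "the series" means these few. Any claim that something is new, unique, unknown or untested is made for them only; others in the source may bear on it.

- Compound 1 `Cc1ccc(/C=C\c2ccc3ccccc3c2)cc1`: > 5000 nM (a limit of the assay, not a number)
- Compound 2 `CN(C)c1ccc(/C=C/c2ccc3ccccc3c2)cc1`: 3660 nM

The two compounds were tested in a functional assay on A549 cells (Homo sapiens) for inhibition; on this read-out higher numbers stand for weaker inhibition and lower numbers for stronger inhibition. Among the compounds with values here, there, compound 2 gives 3660 nM, the only actual number so far. The only other result, for compound 1, is a limit.

The next compound is compound 3 `CN(C)c1ccc(/C=C\c2ccc3ccccc3c2)cc1`. Going from compound 2 to compound 3, (the two compounds have the same atoms and bonds and differ only in configuration as drawn: 1 of 1 stereo elements differ; a double bond is drawn E in compound 2 and Z in compound 3). The atoms and bonds stay the same, so only the configuration changes: the double bond is drawn E in compound 2 and Z in compound 3.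

Within the data shown here, no two measured compounds differ in just one place, so the data do not show directly what such a change does. The step of a 1.5-fold lower number from compound 2 to compound 3 (0.17 log units; within the scatter) is therefore expected to be small, within the usual scatter, with only a slight lean towards stronger inhibition. Compound 3 is estimated at 2500 nM, with an expected range of 400 nM to 9000 nM.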

Compound 3, half-maximal inhibitory concentration: 3660 nM
For compound 3 the middle estimate is 1.5-fold (0.17 log units) below the measured one; the range from low to high includes it.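

In this assay the geometry of this double bond makes no visible difference, with no change at the digits printed from compound 2 to compound 3 (within the scatter), and the comparison is a clean one for a simple reason: the fact that compounds 2 and 3 differ only in the configuration as drawn. Within the data shown here, changing the group on the ring gives an at least 1.3-fold lower number from compound 1 to compound 3 (0.13 log units; that floor lies within the scatter), the first look at dimethylamino in place of methyl on an aromatic carbon. For compound 1 the reading is a limit and not a number, so that step is only a floor, because of this: the limit of > 5000 nM in this assay, at which 1 of the 3 values shown sits.

Still open, going by these compounds, is how much the group at this place matters, since a primary amine, a methoxy group or a carboxylic acid in place of dimethylamino could shift the number in either direction. Also open, on these data alone, is whether the double bond itself is needed, which a saturated two-carbon link would test.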